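The compounds below may be only part of what the source reports. "The series", "measured", "known", "first", "only" and "open" are said of these compounds alone.

Measured compounds:
compound 1 `Clc1ccc(C2=CC3CNCC(C2)C3)cn1` — 35 nM
compound 2 `C1=C(c2cncnc2)CC2CNCC1C2` — 162 nM

In an in vitro functional assay on SH-EP1 cells for agonist activity at Neuronal acetylcholine receptor; alpha4/beta2 (Homo sapiens), read by FLIPR and calcium flux (on this read-out higher numbers stand for an effect only at larger amounts of compound and lower numbers for an effect already at smaller amounts), compound 1 gives 35 nM, the lowest of the two numbers. Its nearest neighbour, compound 2, gives 162 nM, a gap that lies beyond the scatter, so compound 1 stands as the more potent of the two measured compounds.

The step to compound 3 `C1=C(c2ccc(-c3ccccc3)nc2)CC2CNCC1C2` keeps the shared core and changes only the six-membered aromatic ring with one nitrogen: phenyl in place of chloro on an aromatic carbon, the new group sitting next to the ring nitrogen. Among the measured compounds shown here, no measured pair shows the effect of such an exchange, so the expectation rests on compound 1 alone. A considerably larger group in place of a single chlorine at that position is expected to weaken the effect, and the step of a 7.1-fold higher number from compound 1 to compound 3 (0.85 log units; beyond the scatter) is estimated to be a loss beyond the scatter. Compound 3 is therefore expected to give about 250 nM, within a range from 60 nM to 1500 nM.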

Compound 3, half-maximal effective concentration: 9660 nM
For compound 3 the middle estimate is 39-fold (1.59 log units) below the measured one; the measured number lies above the stated range.
By their numbers in this assay, from the lowest: compound 1; then compound 2; then compound 3.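

At the aromatic carbon next to the ring nitrogen, phenyl in place of chloro is far from neutral: in this assay the exchange gives a 280-fold higher number from compound 1 to compound 3 (2.44 log units; beyond the scatter) and so shows that this position responds strongly to the group it carries. The change takes the group from 1 heavy atom to 6 and adds an aromatic ring of carbon only, while the counts of hydrogen-bond donors and acceptors stay at 0 on both sides, so the large loss comes without any change in those counts. Nothing measured here explains the loss.

This single pair cannot separate the effect of the added heavy atoms from that of the aromatic ring itself, and a methyl, a methoxy or an amine at the same place would help to do so. It also leaves open whether a phenyl bearing a hydroxyl group would fare any differently.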